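Pyridin-4-yl Amide Replaces 4-Cyanophenyl on the Shared Core

This account rests on a few compounds, and the source may have more. Where it says the series, first, only, none or still open, it means among the compounds named here.

Compound 1 `CN1CCC(c2c[nH]c3cnc(NC(=O)c4ccc(F)cc4)cc23)CC1` gives 53 nM in an assay for binding affinity to 5-hydroxytryptamine receptor 1D (Homo sapiens), read by radioligand binding; on this read-out lower numbers stand for stronger inhibition and higher numbers for weaker inhibition.
Compound 2 `Cc1cccc(C(=O)Nc2ccc3[nH]cc(C4CCN(C)CC4)c3n2)c1` gives 490 nM in this assay.
Compound 3 `CN1CCC(c2c[nH]c3ccc(NC(=O)c4ccc(C#N)cc4)nc23)CC1` gives 380 nM in this assay.

Among these three numbers compound 3 stands second highest. Its nearest neighbour is compound 2, whose number is higher by an amount within the scatter; the furthest is compound 1, whose number is lower by an amount beyond the scatter. Compound 1 differs from compound 3 in more than one place, so its two values are only compared, not read as a step.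

The new member, compound 4 `CN1CCC(c2c[nH]c3ccc(NC(=O)c4ccncc4)nc23)CC1`, differs from compound 3 by pyridin-4-yl in place of 4-cyanophenyl on a carbonyl carbon.

Going by the values given here, only one measured step touches the group on the carbonyl carbon: a 1.3-fold lower number from compound 2 to compound 3 (0.11 log units; within the scatter). That exchange of one aromatic substituent for another left the number essentially where it was. Among the compounds with values here, no measured step involves a pyridin-4-yl, so the present change has no direct precedent here. Within the data shown here, on the single step available, the swap of one six-membered aromatic ring for another at this position is expected to move this assay little, with no direction favoured beyond the scatter; the expected step is a 1.1-fold higher number from compound 3 to compound 4 (0.02 log units; within the scatter).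

Compound 4 is therefore estimated at 400 nM, with a range from 150 nM to 1100 nM.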

Compound 4, inhibition constant: 420 nM
Compound 4: middle estimate off by 1.1-fold (0.02 log units), on the low side; low and high end bracket the measured number.
By their numbers in this assay, from the lowest: compound 1; then compounds 3, 4 and 2 (each within the scatter of the next).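

In this assay the exchange reads as a step of a 1.1-fold higher number from compound 3 to compound 4 (0.04 log units; within the scatter) and, against the 3-methylphenyl amide, as a step of a 1.2-fold lower number from compound 2 to compound 4 (0.07 log units; within the scatter), so both lie within the scatter. Going by these compounds alone, until now the only step on the carbonyl carbon joined two aromatic rings of carbon only; this result extends that to a six-membered aromatic ring with a hetero atom, and to a group of fewer heavy atoms that lacks the triple bond of the nitrile. On the shared core, compounds 2, 3 and 4 therefore stand within the scatter of each other with three different aromatic groups on the amide, although nothing at hand explains this.

The compounds shown leave open whether this tolerance extends beyond six-membered aromatic rings, for instance to a saturated piperidine, a carboxylic acid or a longer alkyl chain on the carbonyl carbon. Within the data shown here, they also leave open how much of the value of compound 1 (53 nM) belongs to its 4-fluorophenyl group and how much to its different core, as no single-place step links it to the others.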